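A few compounds are considered here, and "the series" means these few. Any claim that something is new, unique, unknown or untested is made for them only; others in the source may bear on it.

Compound 1 `Nc1cc(N)c2nc(-c3ccccc3)c(Oc3ccc(Cl)c(Cl)c3)nc2c1`: 10200 nM
Compound 2 `CCOC(=O)[C@H](CCC(=O)O)NC(=O)c1ccc(Oc2nc3cc(N)cc(N)c3nc2-c2ccccc2)cc1`: 11200 nM

Both numbers come from a functional assay on MDA-MB-231 cells (Homo sapiens) for inhibition, read by sulforhodamine B assay, with a stated time of 48 h; on this read-out lower numbers stand for stronger inhibition of growth and higher numbers for weaker inhibition of growth. Compound 1 gives 10200 nM there, and compound 2 gives 11200 nM; the gap between them sits within the usual scatter of repeated measurements, so nothing separates the two on these numbers. Among the measured compounds shown here, no pair of measured compounds differs in only one place, so no single structural change has a known effect in this set. Compound 3 `Nc1cc(N)c2nc(-c3ccccc3)c(Sc3ccc(F)cc3)nc2c1` has not been measured; it differs from compound 1 by (4-fluorophenyl)sulfanyl in place of 3,4-dichlorophenoxy on an aromatic carbon. For the measured compounds named here, with no comparable step to draw on, the expectation is that the step from compound 1 to compound 3 in this assay is no larger than the scatter, in either direction. Compound 3 is therefore expected to give about 10000 nM in this assay, within a range from 3000 nM to 33000 nM. That estimate means a 1.0-fold lower number from compound 1 to compound 3 (0.01 log units; within the scatter) is expected to stay within the scatter.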

Compound 3, concentration for 50% growth inhibition: 17400 nM
Beside the measured number, compound 3's estimate is 1.7-fold (0.24 log units) below it; the range from low to high includes it.
By their numbers in this assay, from the lowest: compounds 1, 2 and 3 (each within the scatter of the next).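

Among the compounds shown here, this is the first step that can be read at this position, the aromatic carbon next to the ring nitrogen. In this assay, putting (4-fluorophenyl)sulfanyl in place of 3,4-dichlorophenoxy gives a 1.7-fold higher number from compound 1 to compound 3 (0.23 log units; within the scatter), so this exchange of one aryl group for another, which alters both the linking atom and the halogens on the ring, does not clearly separate the two compounds. No measurement here accounts for this result.

For the compounds shown here, the single step cannot show whether the linking atom or the ring halogens would matter on their own, since both change together. It also leaves open how growth inhibition would respond to a group of another kind at this position, such as an amine or a longer alkyl chain.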